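Solubility notes on two benzimidazolone analogues and a third

The source may report more compounds than this note shows. Statements on the series, on what has been measured and on what is new or still open speak of the compounds shown alone.

Measured compounds:
- Compound 1 `Cc1ccc(-n2c(=O)n(-c3ccc(C#N)c(C(F)(F)F)c3)c3ccccc32)cc1` gives 790 nM
- Compound 2 `CC(c1nc(-c2ccccn2)no1)n1c(=O)n(-c2ccc(C#N)c(Cl)c2)c2ccccc21` gives 9450 nM

The read-out is a physicochemical assay for solubility; on this read-out lower numbers stand for lower solubility and higher numbers for higher solubility. Of the two numbers in this assay, compound 1 holds the lower, and compound 2 stands above it by a gap that lies beyond the scatter. Compounds 1 and 2 differ at more than one place, so the gap between them is not tied to a single change; it shows only that the series spans a wide range in this assay.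

Compound 3 `N#CCn1c(=O)n(-c2ccc(C#N)c(C(F)(F)F)c2)c2ccccc21` is not yet measured. Against compound 1 the difference is cyanomethyl in place of 4-methylphenyl on an aromatic nitrogen. The shared core and the group on the other ring nitrogen are kept.

Going by the values given here, no measured pair differs in one place, so the size of this step has no direct precedent. The step is expected to raise solubility: a 3.2-fold higher number from compound 1 to compound 3 (0.50 log units; beyond the scatter) is estimated as a moderate upward move from compound 1, beyond the scatter but well short of the gap to compound 2.

For compound 3 the estimated solubility is 2500 nM, within a range of 800 nM to 8000 nM.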

Compound 3, solubility: 18900 nM
Estimate against measurement, compound 3: 7.6-fold (0.88 log units) below, and the stated range ends below it.
By their numbers in this assay, from the lowest: compound 1; then compounds 2 and 3 (each within the scatter of the next).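

In this assay, going by these compounds alone, the exchange of 4-methylphenyl for cyanomethyl on an aromatic nitrogen gives a 24-fold higher number from compound 1 to compound 3 (1.38 log units; beyond the scatter) and is the first change that can be read at a single place. With the shared core and the group on the other ring nitrogen kept, this position is shown to have a large effect on the read-out, in a step that replaces a six-membered aromatic ring of carbon only, with 7 heavy atoms, by a ringless group of 3 heavy atoms that has 1 triple bond and 1 hydrogen-bond acceptor. No supporting measurement bears on what lies behind this step.

This single pair leaves open which of these differences carries the step: the loss of the ring, the smaller group or the nitrile. Simple methyl, a longer chain ending in a nitrile, or an amine at the same nitrogen would begin to separate these differences and show whether the step holds across other groups at this position.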